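The source may report more compounds than this note shows. Statements on the series, on what has been measured and on what is new or still open speak of the compounds shown alone.

Measured in a physicochemical assay for solubility; a lower number here means a less soluble compound, a higher number a more soluble compound:

- Compound 1 `CS(=O)(=O)N(CCCO)c1c(Cl)c(Cl)cc2[nH]c(=O)c(=O)[nH]c12`: 76 ug/mL
- Compound 2 `Cc1cc2[nH]c(=O)c(=O)[nH]c2c(N(CC(=O)O)S(C)(=O)=O)c1Cl`: 72 ug/mL

In this assay, compound 2 gives 72 ug/mL and compound 1 gives 76 ug/mL. These two values lie within the usual scatter of each other, so neither compound can be ranked over the other.

The next compound to be tested is compound 3 `CS(=O)(=O)N(CC(=O)O)c1c(Cl)c(Cl)cc2[nH]c(=O)c(=O)[nH]c12`. It differs from compound 2 by one change (chloro in place of methyl on an aromatic carbon), which is chloro in place of methyl on an aromatic carbon, ortho to a chloro group.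

For the measured compounds named here, no two measured compounds differ in just one place, so the data give no direct measure of this swap. The only anchor for the estimate is compound 2 at 72 ug/mL, and no step beyond the scatter is expected in this assay, in either direction. The expected change is a 1.0-fold lower number from compound 2 to compound 3 (0.01 log units; within the scatter), a small estimated step that carries wide uncertainty. For compound 3 the estimated solubility is 70 ug/mL, with an expected range from 30 ug/mL to 165 ug/mL.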

Compound 3, solubility: 76 ug/mL
The estimate for compound 3 lay 1.1-fold (0.04 log units) below the measured number; measured number inside the range.
By their numbers in this assay, from the lowest: compounds 2, 1 and 3 (each within the scatter of the next).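

In this assay, the swap of chloro in place of methyl on an aromatic carbon, ortho to a chloro group, can now be read directly: it gives a 1.1-fold higher number from compound 2 to compound 3 (0.02 log units; within the scatter) with the carboxy side chain held constant. Compound 3 also supplies a second single-place comparison, which the earlier pair could not provide, since compound 1 and compound 2 differ in two places: carboxy in place of 2-hydroxyethyl on a saturated chain carbon bound to a sulfonamide nitrogen gives no change at the digits printed from compound 1 to compound 3 (within the scatter) with both chloro groups held constant. Each swap therefore leaves the solubility reading indistinguishable from that of its partner compound, and no supporting data are available to explain this.

From the compounds shown here alone, whether this holds for other groups on the same aromatic carbon, such as fluoro, methoxy or a nitrile, remains open, as does whether the chloro-for-methyl step would be the same with a hydroxyl-bearing side chain in place of the carboxy one. Going by these compounds, on the sulfonamide nitrogen, the reading for an amine or a longer chain also remains open.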